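Swapping Chloro for Fluoro in a Shared Core

The compounds below may be only part of what the source reports. "The series", "measured", "known", "first", "only" and "open" are said of these compounds alone.

Four compounds share one core and differ only in the halogens on two aromatic rings. Compound 1 `CC(C)(C)NCc1c(C(=O)O)nn(-c2ccccc2)c1-c1ccc(F)cc1` carries fluoro; compound 2 `CC(C)(C)NCc1c(C(=O)O)nn(-c2ccccc2)c1-c1ccc(Cl)cc1` carries chloro in its place, the change being (chloro in place of fluoro on an aromatic carbon). Compound 3 `CC(C)(C)NCc1c(C(=O)O)nn(-c2ccc(Cl)cc2)c1-c1ccc(F)cc1` differs from compound 1 by chloro in place of hydrogen on an aromatic carbon, and compound 4 `CC(C)(C)NCc1c(C(=O)O)nn(-c2ccc(Cl)cc2)c1-c1ccc(Cl)cc1` combines both chloro groups.

In a functional assay on PC-3 cells (Homo sapiens) for inhibition, read by sulforhodamine B assay, with a stated time of 48 h (on this read-out lower numbers stand for stronger inhibition of growth and higher numbers for weaker inhibition of growth), compound 1 reaches only the limit > 680000 nM. Compound 2 gives 145000 nM in this assay. Compound 3 also stops at the limit > 623000 nM. The chloro-for-fluoro exchange thus brought an at least 4.6-fold lower number from compound 1 to compound 2 (0.67 log units; beyond the scatter). From the compounds shown here alone, the other step, a step that the two limits leave unreadable from compound 1 to compound 3, stays open because the limit of > 680000 nM in this assay, at which 1 of the 3 values shown sits, and the limit of > 623000 nM in this assay, at which 1 of the 3 values shown sits, each bound one of its two values.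

Compound 4 stands to compound 3 as compound 2 stands to compound 1: the change chloro in place of fluoro on an aromatic carbon is the same change, at the same place on the same kind of ring. Compound 4 is therefore expected to show an at least 3.4-fold lower number from compound 3 to compound 4 (0.53 log units; beyond the scatter) in this assay. This expectation rests on an at least 4.6-fold lower number from compound 1 to compound 2 (0.67 log units; beyond the scatter). Compound 4 is estimated at 180000 nM, between 50000 nM and 600000 nM. The estimate is loose, since the step from compound 1 to compound 3 cannot be sized and compound 3 itself shows only a limit.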

Compound 4, concentration for 50% growth inhibition: > 599000 nM
Compound 4 was reported as a limit (the forecaster's own chance of this, stated with the estimate: 25%); at least 3.3-fold (0.52 log units) between middle value and limit.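

In this assay neither the step from compound 1 to compound 3 nor the step onward to compound 4 can be read, because compound 4, like compound 3, stands only as a limit: the limit of > 599000 nM in this assay, at which 1 of the 4 values shown sits. The exchange of 4-fluorophenyl to 4-chlorophenyl, which gave an at least 4.6-fold lower number from compound 1 to compound 2 (0.67 log units; beyond the scatter) on the core of compound 1, is therefore neither confirmed nor ruled out on the core that carries the added chloro, and this one pair offers no test of whether the change travels between the two cores. What can be read is an at least 4.1-fold higher number from compound 2 to compound 4 (0.61 log units; beyond the scatter), the result of chloro in place of hydrogen on an aromatic carbon with the 4-chlorophenyl held fixed, and it speaks for this pair alone.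

The compounds shown leave open whether the difference between fluoro and chloro extends to other groups on these rings, such as bromo, methyl or methoxy. They also leave open how the series would read with a methyl ester or a primary amide in place of the carboxylic acid, or with a smaller amine such as isopropylamine in place of the tert-butylamine.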